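The compounds below may be only part of what the source reports. "The series", "measured", "known", "first", "only" and "open" are said of these compounds alone.

Measured so far in a functional assay on SK-BR-3 cells (Homo sapiens) for antiproliferative activity; on this read-out lower numbers stand for stronger inhibition and higher numbers for weaker inhibition:
compound 1, `COc1ccc(Oc2ccc3cc(NC(=O)c4ccc(O)c(CC=C(C)C)c4)c(=O)oc3c2C)cc1`, giving 42700 nM
compound 2, `COc1cccc(Oc2ccc3cc(NC(=O)c4ccc(OC(C)=O)c(CC=C(C)C)c4)c(=O)oc3c2C)c1`, giving 13700 nM

Compound 2 stands at the lower of the two numbers; compound 1 gives the higher one, and the gap between compound 1 and compound 2 lies beyond the scatter. Compound 3, `COc1cccc(Oc2ccc3cc(NC(=O)c4ccc(O)c(CC=C(C)C)c4)c(=O)oc3c2C)c1`, is not yet measured in this assay. It differs from compound 2 only in hydrogen in place of acetyl on an oxygen on an aromatic ring. Among the compounds with values here, no pair of measured compounds isolates this change: compound 1 and compound 2 differ at this oxygen and also elsewhere in the ether part, so the two values cannot be read as a step for the acetyl alone. Still, compound 1, the compound carrying the hydrogen on this oxygen, gives 42700 nM, the weaker reading of the two. The step from compound 2 to compound 3 is therefore expected to run toward a higher number, of moderate size, a 1.8-fold higher number from compound 2 to compound 3 (0.26 log units; within the scatter), though a result within the scatter would not surprise. For compound 3 the expected value in this assay is 25000 nM, with a range from 9000 nM to 70000 nM.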

Compound 3, half-maximal inhibitory concentration: 33100 nM
Compound 3: middle estimate off by 1.3-fold (0.12 log units), on the low side; measured number inside the range.
By their numbers in this assay, from the lowest: compound 2; then compounds 3 and 1 (each within the scatter of the next).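

In this assay the acetoxy to hydroxy change can now be read on its own, with 3-methoxyphenyl held constant, as a modest step beyond the scatter (a 2.4-fold higher number from compound 2 to compound 3 (0.38 log units; beyond the scatter)), the acetoxy form giving the lower number. With hydroxy held constant, 3-methoxyphenyl in place of 4-methoxyphenyl on the oxygen gives a step within the scatter (a 1.3-fold lower number from compound 1 to compound 3 (0.11 log units; within the scatter)), so this pair shows no separation between the two methoxyphenyl ethers in this assay. No measured evidence bears on the origin of either step.

Going by these compounds, whether a methyl ether or a butanoyl group on the oxygen would read like acetoxy or like hydroxy remains open. Also open, on these data alone, is whether the two methoxyphenyl ethers would stay within the scatter of each other with acetoxy in place of hydroxy.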